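Swapping an amide chain end for methoxy

A few compounds are considered here, and "the series" means these few. Any claim that something is new, unique, unknown or untested is made for them only; others in the source may bear on it.

- compound 1 `C#CCn1c2ccc([N+](=O)[O-])cc2c(=O)n1Cc1ccccc1`: 195000 nM
- compound 2 `CCOC(=O)CCCn1c2ccc([N+](=O)[O-])cc2c(=O)n1Cc1ccccc1`: 78100 nM
- compound 3 `CN(C)C(=O)CCCn1c2ccc([N+](=O)[O-])cc2c(=O)n1Cc1ccccc1`: > 256000 nM (a limit of the assay, not a number)

All three values come from an ADME assay on L929 cells (Mus musculus) for cytotoxicity, read by resazurin assay, with a stated time of 48 h; on this read-out higher numbers stand for lower toxicity in this test and lower numbers for higher toxicity in this test. Compound 3 has no exact value and is known only through (the limit of > 256000 nM in this assay, at which 1 of the 3 values shown sits).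

The next compound is compound 4 `COCCn1c2ccc([N+](=O)[O-])cc2c(=O)n1Cc1ccccc1`. The change is methoxy in place of (dimethylcarbamoyl)methyl on a saturated chain carbon, two bonds along the chain from an aromatic nitrogen.

Within the data shown here, no measured step makes this exact swap, so the estimate rests on neighbouring steps. The closest is an at least 3.2-fold higher number from compound 2 to compound 3 (0.51 log units; beyond the scatter), where only the end of the chain changes, and it shows that this end can matter. Compound 4 has no amide, and neither do compounds 1 and 2. The step of a 2.5-fold lower number from compound 1 to compound 2 (0.40 log units; beyond the scatter) separates those two, while an at least 1.3-fold higher number from compound 1 to compound 3 (0.11 log units; that floor lies within the scatter) stays within the scatter at its floor. A modest move towards a lower number in this assay is therefore expected, landing near compound 1 at 195000 nM and compound 2 at 78100 nM. The expected change is an at least 1.9-fold lower number from compound 3 to compound 4 (0.29 log units; that floor lies within the scatter). For compound 4 the estimated value is 130000 nM, with an expected range of 60000 nM to 256000 nM.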

Compound 4, concentration lethal to 50% of the cells: > 256000 nM
Compound 4: a limit, no number; the forecaster's own chance of this, stated with the estimate: 20%; middle value at least 1.9-fold (0.29 log units) from the limit.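

In this assay, an amide at the chain end is not needed to reach the top of the measurable range, since compound 4 gets there with 2-methoxyethyl in its place. Relative to the ester chain, the methoxy chain gives an at least 3.2-fold higher number from compound 2 to compound 4 (0.51 log units; beyond the scatter), which leaves the ester as the only chain end here that clearly lowers the number, while the comparison with the ethynyl chain gives only an at least 1.3-fold higher number from compound 1 to compound 4 (0.11 log units; that floor lies within the scatter), so no gain over that chain can be claimed. Compound 3 and compound 4 each stand at a limit of the assay rather than at a number, so the step between them cannot be read: the limit of > 256000 nM in this assay, at which 2 of the 4 values shown sit.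

On these data alone, how far apart compound 3 and compound 4 really are, and how far either lies beyond that limit, remains unknown, so the shared limit does not show that the two chains behave alike. The compounds shown also leave open whether the lower number belongs to the ester as such, and what a carboxylic acid or an amine at the chain end, or a longer chain ending in methoxy, would give on this read-out.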